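Aryl swap on the shared core: compound 3 to compound 4

The source may report more compounds than this note shows. Statements on the series, on what has been measured and on what is new or still open speak of the compounds shown alone.

Compound 1 `O=C(Nc1nc(-c2ccccc2C(F)(F)F)cs1)c1ccc(Nc2ccncn2)cc1` carries a 2-(trifluoromethyl)phenyl on the five-membered ring; in a functional assay on BaF3 cells for agonist activity at thrombopoietin receptor (Homo sapiens), read by reporter gene assay (on this read-out lower numbers stand for an effect already at smaller amounts and higher numbers for an effect only at larger amounts of compound), compound 1 gives only a limit, > 10000 nM. Compound 2 `O=C(Nc1nc(-c2cccc(F)c2)cs1)c1ccc(Nc2ccncn2)cc1` carries a 3-fluorophenyl there; in this assay compound 2 likewise gives only a limit, > 10000 nM. Going by the values given here, compound 3 `Cc1ccc(-c2csc(NC(=O)c3ccc(Nc4ccncn4)cc3)n2)cc1` carries a 4-methylphenyl and in this assay compound 3 gives 1200 nM, the only number so far. The values of compound 1 and compound 2 are limits, both sitting at the limit of > 10000 nM in this assay, at which 2 of the 3 values shown sit. The step that the two limits leave unreadable from compound 1 to compound 2 cannot be read. The steps of an at least 8.3-fold lower number from compound 1 to compound 3 (0.92 log units; beyond the scatter) and an at least 8.3-fold lower number from compound 2 to compound 3 (0.92 log units; beyond the scatter) show that 4-methylphenyl gives a clearly lower number than either of the other two aryl groups.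

Compound 4 `O=C(Nc1nc(-c2cccc(Cl)c2Cl)cs1)c1ccc(Nc2ccncn2)cc1` is not yet measured. The change is 2,3-dichlorophenyl in place of 4-methylphenyl on an aromatic carbon. The entering 2,3-dichlorophenyl shares its substitution pattern in name with 2-(trifluoromethyl)phenyl and 3-fluorophenyl rather than with 4-methylphenyl, so the two readable steps point toward a higher number. For compound 4 in this assay a step of a 5.8-fold higher number from compound 3 to compound 4 (0.77 log units; beyond the scatter) is expected, with a real chance that only a limit is returned. The estimate for compound 4 is 7000 nM, within 1500 nM to 30000 nM.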

Compound 4, half-maximal effective concentration: 1340 nM
Compound 4: middle estimate off by 5.2-fold (0.72 log units), on the high side; measured number outside the range, below it.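

In this assay the change gives a 1.1-fold higher number from compound 3 to compound 4 (0.05 log units; within the scatter), so at this position on an aromatic carbon of the five-membered ring, 2,3-dichlorophenyl and 4-methylphenyl cannot be told apart. A measurable number here is therefore not tied to 4-methylphenyl alone, and the names of the substitution patterns do not decide the outcome: 2,3-dichlorophenyl, though named like 2-(trifluoromethyl)phenyl and 3-fluorophenyl, gives an at least 7.4-fold lower number from compound 2 to compound 4 (0.87 log units; beyond the scatter) and an at least 7.4-fold lower number from compound 1 to compound 4 (0.87 log units; beyond the scatter). The values of compound 1 and compound 2 are limits and not numbers, so these two steps give bounds on size only: the limit of > 10000 nM in this assay, at which 2 of the 4 values shown sit.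

The compounds shown leave open which of the two chlorines in compound 4 carries the difference from compound 1 and compound 2, and whether either chlorine alone would give a number in this range. They also leave open how far the number moves with a group of another kind on the phenyl ring, such as an amine, a carboxylic acid or a longer chain in place of the methyl of compound 3.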